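Removing a Chlorine on the Aryl Ring: an Expected Drop

This account rests on a few compounds, and the source may have more. Where it says the series, first, only, none or still open, it means among the compounds named here.

Of the compounds shown here, two of a shared core have been tested in a functional assay on the whole organism (strain Swiss) with Mus musculus as the target, in the maximal electroshock model, with a stated time of 0.25 h, at a dose of 100 mg/kg by the intraperitoneal route; on this read-out lower numbers stand for a weaker effect and higher numbers for a stronger effect at the one dose given. Compound 1, `CCC(C(=O)N1CCN(c2ccccc2F)CC1)N1C(=O)CCC1=O`, gives 0% in this assay. Compound 2, `CC(C(=O)N1CCN(c2ccc(Cl)cc2)CC1)N1C(=O)CCC1=O`, gives 50% in this assay. On these two numbers compound 2 stands highest, and its nearest neighbour, compound 1, lies lower by a gap beyond the usual scatter of the measurement. The two differ in more than one place, so nothing links that gap to any single change.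

Compound 3, `CC(C(=O)N1CCN(c2ccccc2)CC1)N1C(=O)CCC1=O`, has not yet been measured. Compared with compound 2 the change is hydrogen in place of chloro on an aromatic carbon. Only the chlorine is taken away, everything else stays.

For the measured compounds named here, with no measured step of this one change to lean on, the expectation for compound 3 rests on compound 2 alone, which gives 50%. Going by the values given here, a smaller effect is expected, since the only active compound so far carries the chloro group. The step from compound 2 to compound 3 is expected to be a number 20 percentage points lower from compound 2 to compound 3 (beyond the scatter). Compound 3 is therefore estimated at 30%, within a range from 0% to 60%.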

Compound 3, a percentage reported as activity, at one dose (the size of the read-out at that dose, not a potency): 50%
For compound 3 the middle estimate is 20 percentage points below the measured one; low and high end bracket the measured number.
By their numbers in this assay, from the lowest: compound 1; then compounds 2 and 3 (each within the scatter of the next).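

In this assay, for the compounds shown here, the 4-chlorophenyl to phenyl change gives no change at the digits printed from compound 2 to compound 3 (within the scatter), and this is the first comparison here in which only one place differs. At this ring carbon, para to a large group, the chlorine is therefore not needed for the effect seen at this single dose, and a plain hydrogen serves just as well on this read-out. No measurement at hand bears on why the step comes out this way.

On these data alone, whether a methoxy group or an amine on the same ring carbon would keep the effect remains open, as does whether compound 2 and compound 3 would still match at other doses, since one dose gives no potency. Compound 1, at 0%, differs from compound 2 and from compound 3 in more than one place, so the steps to it cannot be read and its result cannot be tied to any single change.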